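The compounds below may be only part of what the source reports. "The series", "measured", "known", "first", "only" and "open" are said of these compounds alone.

Measured so far:
compound 1 `Cc1nnc(SCC(=O)N/N=c2/scc(-c3ccc(Cl)cc3)n2-c2ccccc2)s1`, 29%
compound 2 `O=C(CSc1nnnn1-c1ccccc1)N/N=c1/scc(-c2ccc(Cl)cc2)n1-c1ccccc1`, 52.4%
compound 3 `O=C(CSc1ncccn1)N/N=c1/scc(-c2ccc(Br)cc2)n1-c1ccccc1`, 63.2%

In a functional assay on C6 cells (Rattus norvegicus) for cytotoxicity, read by MTT assay, with a stated time of 24 h, tested at 200 ug/mL (a lower number here means a stronger effect, a higher number a weaker effect of the compound at the concentration tested), compound 3 stands highest of the three numbers, with compound 2 nearest and compound 1 furthest away; both gaps are beyond the scatter, so compound 3 has the weakest effect of the measured compounds at the concentration tested.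

Compound 4 `O=C(CSc1ncccn1)N/N=c1/scc(-c2ccc(Cl)cc2)n1-c1ccccc1` is next, differing from compound 3 by chloro in place of bromo on an aromatic carbon. For the measured compounds named here, the only measured step, a number 23.4 percentage points higher from compound 1 to compound 2 (beyond the scatter), concerns the group on the sulfur, not the halogen on the phenyl, so it does not bear on this change. Going by the values given here, no measured pair differs only in the halogen; compound 2 and compound 3 differ in two places at once, and their values show only the combined result. The change is small in size and alters no hydrogen-bond count, so for compound 4 no step beyond the scatter is expected, a number 3.2 percentage points lower from compound 3 to compound 4 (within the scatter). Compound 4 is therefore estimated at 60% in this assay, within a range of 42% to 76%.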

Compound 4, a percentage reported as activity, at one concentration (the size of the read-out at that concentration, not a potency): 39.7%
Estimate against measurement, compound 4: 20.3 percentage points above; measured number outside the range, below it.
By their numbers in this assay, from the lowest: compound 1; then compound 4; then compound 2; then compound 3.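

In this assay the halogen on the phenyl proves to matter: the change from 4-bromophenyl to 4-chlorophenyl, on an aromatic carbon para to a large group, gives a number 23.5 percentage points lower from compound 3 to compound 4 (beyond the scatter) with no change in ring or hydrogen-bond count. With chloro held fixed, the group on the sulfur now reads across three compounds, with a number 12.7 percentage points lower from compound 2 to compound 4 (beyond the scatter) and a number 10.7 percentage points higher from compound 1 to compound 4 (beyond the scatter) so that pyrimidin-2-yl falls between 1-phenyl-1H-tetrazol-5-yl and 5-methyl-1,3,4-thiadiazol-2-yl.

As far as these compounds go, the halogen step is read only with pyrimidin-2-yl on the sulfur, so whether it holds with the other sulfur groups stays open, as does the outcome of a methoxy group or an amine in this place on the phenyl. Nothing at hand explains the halogen step.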